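The source may hold more compounds than are shown below. What is called first, only, known or untested is meant among the compounds shown, and "the series" means these compounds.

Compound 1, `CCCC(=O)NCCCCc1ccccc1OC`, gives 116 nM in an assay for binding affinity to melatonin receptor (Gallus gallus); on this read-out lower numbers stand for stronger inhibition and higher numbers for weaker inhibition. Compound 2, `CCCCC(=O)NCCCCc1ccccc1OC`, gives 9190 nM. The change between them is methyl in place of hydrogen on a saturated chain carbon, three bonds along the chain from a carbonyl carbon, and it produced a 79-fold higher number from compound 1 to compound 2 (1.90 log units; beyond the scatter). Compound 3, `COc1ccc(CCCCNC(C)=O)cc1`, gives 7300 nM; the difference between the core of compound 3 and that of compound 1 is not broken down here.

Compound 4, `CCC(=O)NCCCCc1ccc(OC)cc1`, has not yet been measured. It differs from compound 3 by methyl in place of hydrogen on a saturated chain carbon bound to a carbonyl carbon, the same kind of change as from compound 1 to compound 2, though the place is not the same: there the methyl entered three bonds along the chain from a carbonyl carbon, here it enters on a saturated chain carbon bound to a carbonyl carbon. Since the place differs, the earlier large step is only a loose guide; a smaller step, a 1.2-fold lower number from compound 3 to compound 4 (0.09 log units; within the scatter), is expected. Compound 4 is estimated at 6000 nM, between 1500 nM and 20000 nM.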

Compound 4, inhibition constant: 1400 nM
The estimate for compound 4 lay 4.3-fold (0.63 log units) above the measured number, outside the stated range (below it).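

In this assay, adding the methyl gave a 5.2-fold lower number from compound 3 to compound 4 (0.72 log units; beyond the scatter), so the large loss seen on the core of compound 1 did not carry over to this core. Set side by side, the two steps run in opposite directions, and the gap between them is real: the same change on two cores in this assay, a 79-fold higher number (1.90 log units; beyond the scatter) from compound 1 to compound 2 and a 5.2-fold lower number (0.72 log units; beyond the scatter) from compound 3 to compound 4, 410-fold (2.62 log units) apart, beyond the scatter of two such steps

This shows that the result of this change on one core cannot simply be transferred to the other, but it does not show why, as the two steps differ in both the core and the place of the methyl, and these compounds do not separate the two. Still open, on these data alone, is what the methyl does on the core of compound 3 when it enters three bonds along the chain from a carbonyl carbon. Also open, as far as these compounds go, is how a longer chain than propanoyl would behave on that core.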